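Methoxy on the benzyl of an indazolyl sulfonamide piperidine carboxamide

A few compounds are considered here, and "the series" means these few. Any claim that something is new, unique, unknown or untested is made for them only; others in the source may bear on it.

Measured so far:
compound 1, `CCN(Cc1ccccc1)C(=O)C1CCN(S(=O)(=O)c2ccccc2)CC1`, 69%
compound 2, `CCN(Cc1ccccc1)C(=O)C1CCN(S(=O)(=O)c2ccc3cn[nH]c3c2)CC1`, 86%

In a functional assay on CHO cells for positive allosteric modulation of muscarinic acetylcholine receptor M5 (Homo sapiens), read by calcium flux (on this read-out higher numbers stand for larger maximal responses and lower numbers for smaller maximal responses), compound 2 stands highest of the two numbers; its nearest neighbour is compound 1, and the step of a number 17 percentage points higher from compound 1 to compound 2 (beyond the scatter) came from replacing phenyl on the sulfonyl sulfur by 1H-indazol-6-yl. Compound 3, `CCN(Cc1cccc(OC)c1)C(=O)C1CCN(S(=O)(=O)c2ccc3cn[nH]c3c2)CC1`, differs from compound 2 by methoxy in place of hydrogen on an aromatic carbon, that is, benzyl to 3-methoxybenzyl. Going by the values given here, no measured step touches the benzyl group, so the one known step gives no guide here. A step within the scatter is expected, no change at the digits printed from compound 2 to compound 3 (within the scatter). Compound 3 is therefore estimated at 86%, between 70% and 98%.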

Compound 3, largest response reached (reported as percent of maximum), in percent of the reference or control that the assay uses: 85%
The estimate for compound 3 lay 1 percentage points above the measured number; low and high end bracket the measured number.
By their numbers in this assay, from the lowest: compound 1; then compounds 3 and 2 (each within the scatter of the next).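

In this assay, 3-methoxybenzyl in place of benzyl gives a number 1 percentage points lower from compound 2 to compound 3 (within the scatter), so compound 2 and compound 3 cannot be told apart. Going by these compounds alone, this is the first read on the benzyl group, and it shows that a methoxy on this aromatic carbon, meta to a large group, is tolerated at the high response of compound 2. No supporting data bear on this result.

As far as these compounds go, whether this tolerance extends to other groups at this place, such as a dimethylamino group or a carboxylic acid, remains open. Also open, from the compounds shown here alone, is what a longer chain in place of the ethyl on the amide nitrogen would give.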